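Series notes: from compound 2 to compound 4

The source may report more compounds than this note shows. Statements on the series, on what has been measured and on what is new or still open speak of the compounds shown alone.

Measured in a functional assay on U-87MG ATCC cells for antiproliferative activity against U-87 MG (Homo sapiens), read by MTT assay, with a stated time of 48 h; on this read-out lower numbers stand for stronger inhibition and higher numbers for weaker inhibition:
- compound 1 `COc1ccc(-c2nc(C)c(C(=O)CSc3nc(-c4cccc(OC)c4)c(C#N)c(=O)[nH]3)s2)cc1`: 15300 nM
- compound 2 `COc1cccc(-c2nc(SCC(=O)c3sc(-c4ccccc4)nc3C)[nH]c(=O)c2C#N)c1`: 59700 nM
- compound 3 `COc1ccc(-c2nc(C)c(C(=O)CSc3nc(-c4ccc(OC)c(OC)c4)c(C#N)c(=O)[nH]3)s2)cc1`: 12500 nM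

Compound 2 has the highest of the three numbers, and compound 1 and compound 3 both lie lower, beyond the scatter. Compound 4 `Cc1nc(-c2ccccc2)sc1C(=O)CSc1nc(-c2ccccc2)c(C#N)c(=O)[nH]1` differs from compound 2 by hydrogen in place of methoxy on an aromatic carbon, that is, 3-methoxyphenyl to phenyl. Two measured steps exchange hydrogen and methoxy on an aromatic carbon, though neither is this exact change. Adding methoxy gives a 1.2-fold lower number from compound 1 to compound 3 (0.09 log units; within the scatter), within the scatter. Removing methoxy gives a 3.9-fold higher number from compound 1 to compound 2 (0.59 log units; beyond the scatter), modest but beyond it. A small rise in this assay is therefore expected, possibly none beyond the scatter. The estimated step is a 1.1-fold higher number from compound 2 to compound 4 (0.04 log units; within the scatter). For compound 4 the estimate is 65000 nM, with an expected range of 28000 nM to 150000 nM.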

Compound 4, half-maximal inhibitory concentration: 56600 nM
Beside the measured number, compound 4's estimate is 1.1-fold (0.06 log units) above it; measured number inside the range.
By their numbers in this assay, from the lowest: compounds 3 and 1 (each within the scatter of the next); then compounds 4 and 2 (each within the scatter of the next).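

In this assay, replacing methoxy with hydrogen in the 3-methoxyphenyl to phenyl change gives a 1.1-fold lower number from compound 2 to compound 4 (0.02 log units; within the scatter), so this position tolerates losing the methoxy with no change that can be read. Unlike a 3.9-fold higher number from compound 1 to compound 2 (0.59 log units; beyond the scatter), where a methoxy is lost elsewhere on the molecule, this step stays inside the scatter. Exchanging hydrogen and methoxy on an aromatic carbon of this ring now reads as silent on two cores: the same change on two cores in this assay, a 1.2-fold lower number (0.09 log units; within the scatter) from compound 1 to compound 3 and a 1.1-fold higher number (0.02 log units; within the scatter) from compound 4 to compound 2, 1.3-fold (0.11 log units) apart, within the scatter of two such steps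

On these data alone, whether an amine, a carboxylic acid or a longer alkoxy chain at this position would move the number remains open.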